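Shrinking the Oxan-2-yl Ring: Cytotoxicity Expectation for Compound 3

The source may report more compounds than this note shows. Statements on the series, on what has been measured and on what is new or still open speak of the compounds shown alone.

Compound 1 `COc1ccc(CNc2ncnc3c2ncn3C2CCCCO2)c(OC)c1` — > 25000 nM
Compound 2 `COc1ccc(CNc2ncnc3c2ncn3C2CCCCO2)c(OC)c1OC` — > 37500 nM

Of the compounds shown here, two sharing one core have been tested in an ADME assay on BJ cells (Homo sapiens) for cytotoxicity, read by MTT assay, with a stated time of 72 h; a higher number here means a weaker inhibitor, a lower number a stronger inhibitor. Compound 1 gives only a limit, > 25000 nM, rather than a number. Compound 2 likewise gives only a limit, > 37500 nM, in this assay. Within the data shown here, the single measured step, a step that the two limits leave unreadable from compound 1 to compound 2, cannot be sized because the limit of > 25000 nM in this assay, at which 1 of the 2 values shown sits, and the limit of > 37500 nM in this assay, at which 1 of the 2 values shown sits, both describe limits rather than numbers. Among the measured compounds shown here, compound 2 therefore stands at a limit with no measurable cytotoxicity in this assay, and the only other value shown is a limit as well.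

Compound 3 `COc1ccc(CNc2ncnc3c2ncn3C2CCCO2)c(OC)c1OC` differs from compound 2 by oxolan-2-yl in place of oxan-2-yl on an aromatic nitrogen. For the measured compounds named here, no measured step touches this part of the molecule, and the one step that exists is unreadable, so there is nothing to suggest a change beyond the scatter in this assay. Compound 3 is expected to give about 37500 nM, with a range from 15000 nM to 80000 nM. The estimated step of a number no higher from compound 2 to compound 3 (the limit leaves the size open) is expected to stay within the scatter, most likely as another limit.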

Compound 3, half-maximal inhibitory concentration: > 100000 nM
Compound 3: only a limit was reported; the forecaster's own chance of this, stated with the estimate: 80%; at least 2.6-fold (0.42 log units) between middle value and limit.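

In this assay, compound 3 gives > 100000 nM, a limit rather than a number. Compound 2 also gives a limit, > 37500 nM, so no step can be read between compound 2 and compound 3. The compounds shown leave open how oxolan-2-yl and oxan-2-yl compare on the aromatic nitrogen in this assay, where none yields a number.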